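The source may report more compounds than this note shows. Statements on the series, on what has been measured and on what is new or still open speak of the compounds shown alone.

Measured in a functional assay on HepG2 cells (Homo sapiens) for antiproliferative activity, read by MTT assay; on this read-out lower numbers stand for stronger inhibition and higher numbers for weaker inhibition:
compound 1 `O=C1N=C(N2CCC[C@H]2C(=O)Nc2ccc3ncnc(Nc4cccc(Cl)c4)c3c2)S/C1=C/c1ccc(Br)s1` gives only a limit, > 50000 nM.
compound 2 `O=C1N=C(N2CCC[C@H]2C(=O)Nc2ccc3ncnc(Nc4cccc(Cl)c4)c3c2)S/C1=C/c1ccccc1Cl` gives 28100 nM.
compound 3 `Cc1cccc(/C=C2/SC(N3CCC[C@H]3C(=O)Nc3ccc4ncnc(Nc5cccc(Cl)c5)c4c3)=NC2=O)n1` gives 4500 nM.

Compound 2 holds the highest of the two numbers, with compound 3 as its nearest neighbour at a 6.2-fold lower number from compound 2 to compound 3 (0.80 log units; beyond the scatter). Compound 1 sits at a limit (the limit of > 50000 nM in this assay, at which 1 of the 3 values shown sits), so the steps of an at least 1.7-fold lower number from compound 1 to compound 2 (0.25 log units; that floor lies within the scatter) and an at least 11-fold lower number from compound 1 to compound 3 (1.04 log units; beyond the scatter) carry only floors, the first of them within the scatter.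

The step to compound 4 `O=C1N=C(N2CCC[C@H]2C(=O)Nc2ccc3ncnc(Nc4cccc(Cl)c4)c3c2)S/C1=C/c1ccc(-c2ccccc2)cc1` reads: 4-phenylphenyl in place of 2-chlorophenyl on a double-bonded chain carbon bound to a double-bonded ring carbon. The measured steps all concern this same position, and they show that exchanging the aryl group there can move the number markedly, as with compound 3. Among the measured compounds shown here, no measured compound carries a 4-phenylphenyl group, and no step distinguishes one ring from two at this position, so the direction is open. The expected step of a 1.6-fold lower number from compound 2 to compound 4 (0.19 log units; within the scatter) is therefore set near the scatter, leaning slightly lower. Compound 4 is estimated at 18000 nM, within a range of 3500 nM to 60000 nM.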

Compound 4, half-maximal inhibitory concentration: 15400 nM
Compound 4: middle estimate off by 1.2-fold (0.07 log units), on the high side; low and high end bracket the measured number.
By their numbers in this assay, from the lowest: compound 3; then compounds 4 and 2 (each within the scatter of the next). At a limit, above all of these: compound 1.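

Going from one ring to two at this position gives a 1.8-fold lower number from compound 2 to compound 4 (0.26 log units; within the scatter), so 4-phenylphenyl and 2-chlorophenyl cannot be told apart here, and the added ring does not move the number beyond the scatter. The gap to the 6-methylpyridin-2-yl group remains, at a 3.4-fold higher number from compound 3 to compound 4 (0.53 log units; beyond the scatter), so the larger carbon-only biaryl does not match compound 3. Against 5-bromothiophen-2-yl the step is an at least 3.2-fold lower number from compound 1 to compound 4 (0.51 log units; beyond the scatter), which is a floor only, as compound 1 sits at a limit: the limit of > 50000 nM in this assay, at which 1 of the 4 values shown sits.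

Whether the lower number of compound 3 goes with its ring nitrogen or with its methyl stays open, as no compound shown separates the two. Also open, on these data alone, is how a plain pyridin-2-yl, or a phenyl carrying an amine or a carboxylic acid, would read at this position.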